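Methyl for Pyrrolidinyl on a Pyridazinone-Type Cyanoguanidine Series

The compounds below may be only part of what the source reports. "The series", "measured", "known", "first", "only" and "open" are said of these compounds alone.

Compound 1 `C/N=C(/NC#N)NCCCCn1nc(N2CCCC2)ccc1=O`: -1%
Compound 2 `C/N=C(/NC#N)NCCCCCn1nc(C)ccc1=O`: 14.9%
Compound 3 `CCC/N=C(/NC#N)NCCCn1nc(-c2ccccc2)ccc1=O`: 52.9%

Three cyanoguanidines sharing one core have been tested in a functional assay on the whole organism with Rattus norvegicus as the target, at a dose of 100 mg/kg; a lower number here means less inhibition, a higher number more inhibition at the dose given (going by the name of the read-out). Compound 1 gives -1%, the lowest of the three numbers. Compound 2 sits next to it at 14.9%, a gap beyond the usual scatter, and compound 3 stands furthest at 52.9%, likewise beyond the scatter. No pair of these compounds differs in a single place, so the numbers alone are known, not the size of any one change.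

Compound 4 `C/N=C(/NC#N)NCCCCn1nc(C)ccc1=O` has not been measured. It differs from compound 1 in one place: methyl in place of pyrrolidin-1-yl on an aromatic carbon. Compound 2 also carries a methyl on the core and gives 14.9%, which offers some orientation. A small upward step is expected in this assay, probably at the edge of the scatter rather than clearly beyond it. Compound 4 is estimated at 8%, with a range from -10% to 25%. The expected step is a number 9 percentage points higher from compound 1 to compound 4 (within the scatter).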

Compound 4, a percentage reported as inhibition, in the whole organism at one dose (the size of the read-out at that dose, not a potency): 23.5%
Compound 4: middle estimate off by 15.5 percentage points, on the low side; the range from low to high includes it.
By their numbers in this assay, from the lowest: compound 1; then compounds 2 and 4 (each within the scatter of the next); then compound 3.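

In this assay, putting methyl in place of pyrrolidin-1-yl on the aromatic carbon gives a number 24.5 percentage points higher from compound 1 to compound 4 (beyond the scatter), the first single change the series allows to be read. It shows that the group at this position bears on the inhibition seen at this dose, with the smaller, ring-free methyl on the higher side of the step. The change swaps a five-membered non-aromatic ring holding a nitrogen for one carbon, and nothing on hand explains the step.

A single pair cannot separate the loss of the ring from the loss of the ring nitrogen or from the drop in size. Going by these compounds, a dimethylamino group, a morpholin-4-yl ring or an ethyl group at the same carbon would bear on that question, and how far the step holds on other chains also remains open.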